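The source may report more compounds than this note shows. Statements on the series, on what has been measured and on what is new or still open speak of the compounds shown alone.

Notes on the series. Compound 1 `CCCCN(c1nc2c(CO)cccc2o1)[C@H](C)c1ccc(-c2ccccc2-c2nnn[nH]2)cc1` gives 1.6 h in an ADME assay on the whole organism (Macaca fascicularis) for metabolic stability, read by LC-MS, using cassette dosing, at a dose of 1 mg/kg by the oral route (on this read-out lower numbers stand for a shorter-lived compound and higher numbers for a longer-lived compound), and compound 2 `CCCCN(c1nc2c(C(=O)NC)cccc2o1)[C@H](C)c1ccc(-c2ccccc2-c2nnn[nH]2)cc1` gives 1.3 h in this assay. Going by the values given here, the only single-point step measured so far, a 1.2-fold lower number from compound 1 to compound 2 (0.09 log units; within the scatter), lies within the scatter. Compound 3 `C[C@H](c1ccc(-c2cc(F)ccc2-c2nc(=O)o[nH]2)cc1)N(CC1CC1)c1nc2c(C(=O)O)cccc2o1` gives 4.1 h in this assay, the highest of the three numbers, with its gaps to compound 1 and to compound 2 both beyond the scatter. Compound 4 `C[C@H](c1ccc(-c2cc(Cl)ccc2-c2nc(=O)o[nH]2)cc1)N(CC1CC1)c1nc2c(C(=O)O)cccc2o1` has not been measured; it differs from compound 3 by chloro in place of fluoro on an aromatic carbon. Among the compounds with values here, no measured step bears on this exchange: the single recorded step concerns a different group at a different place on the shared core, was within the scatter, and gives no guide to swapping fluoro for chloro. On the numbers in hand, the change is expected to move this assay little, with no step beyond the scatter. Compound 4 is therefore expected to give about 4 h in this assay, within 2 h to 8 h, an expected step of a 1.0-fold lower number from compound 3 to compound 4 (0.01 log units; within the scatter).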

Compound 4, half-life: 0.8 h
Compound 4: the middle estimate sits 5.0-fold (0.70 log units) above what was measured; measured number outside the range, below it.
By their numbers in this assay, from the lowest: compounds 4, 2 and 1 (each within the scatter of the next); then compound 3.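

At this position, on an aromatic carbon meta to a large group and para to a group of 6 heavy atoms, the exchange of one halogen for another is not neutral in this assay: chloro in place of fluoro gives a 5.1-fold lower number from compound 3 to compound 4 (0.71 log units; beyond the scatter). Going by these compounds alone, the only earlier single-point step, a 1.2-fold lower number from compound 1 to compound 2 (0.09 log units; within the scatter), concerned another place and another pair of groups, and it stayed within the scatter. Here the exchange of one heavy atom for another, with no change in the counted donors, acceptors or charge, is enough to move the half-life beyond the scatter, and nothing at hand gives a cause for this.

With only fluoro and chloro shown here, the compounds leave open whether a methyl group or a nitrile at this aromatic carbon would stay closer to compound 3 or to compound 4. They also leave open whether the same exchange would give a similar step with a butyl chain in place of the cyclopropylmethyl group.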